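A few compounds are considered here, and "the series" means these few. Any claim that something is new, unique, unknown or untested is made for them only; others in the source may bear on it.

Measured so far:
- Compound 1 `C#CCOc1ccc2c(=O)c(-c3cc(OC)c(OC)cc3OC)coc2c1` gives > 10000 nM, which is a limit of the assay rather than a number.
- Compound 2 `COc1cc(OC)c(-c2coc3cc(OCc4ccccc4F)ccc3c2=O)cc1OC` gives 4300 nM.
- Compound 3 `COc1cc(OC)c(-c2coc3cc(OCc4ccc(Br)cc4)ccc3c2=O)cc1OC` gives > 10000 nM, again a limit and not a number.

All three were tested in a functional assay on HUVEC cells (Homo sapiens) for antiproliferative activity, read by MTT assay, with a stated time of 24 h; on this read-out lower numbers stand for stronger inhibition and higher numbers for weaker inhibition. Compound 1 stands at the weak end of what is shown: only a limit is known for it, and (the limit of > 10000 nM in this assay, at which 2 of the 3 values shown sit). Compound 4 `COc1cc(OC)c(-c2coc3cc(OCc4cccc(C(F)(F)F)c4)ccc3c2=O)cc1OC` has not yet been measured. It differs from compound 1 in one place: 3-(trifluoromethyl)phenyl in place of ethynyl on a saturated chain carbon bound to an oxygen on an aromatic ring.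

Two measured steps start from the same compound 1 and put a substituted phenyl in the same place. One is an at least 2.3-fold lower number from compound 1 to compound 2 (0.36 log units; beyond the scatter), the other is a step that the two limits leave unreadable from compound 1 to compound 3. Between those two products the difference is an at least 2.3-fold higher number from compound 2 to compound 3 (0.36 log units; beyond the scatter). So a phenyl bearing a halogen in this position can bring the number down modestly or leave it at the limit, and the new 3-(trifluoromethyl)phenyl cannot be placed on either side from what is shown.

Compound 4 is therefore expected to give about 7000 nM, with a range from 2500 nM to 20000 nM. The expected step is an at least 1.4-fold lower number from compound 1 to compound 4 (0.15 log units; that floor lies within the scatter), small or none beyond the scatter, with a real chance that only a limit is reported.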

Compound 4, half-maximal inhibitory concentration: > 10000 nM
Compound 4 ended at the assay's limit; the forecaster's own chance of this, stated with the estimate: 50%; at least 1.4-fold (0.15 log units) between middle value and limit.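

Putting 3-(trifluoromethyl)phenyl in place of 2-fluorophenyl gives an at least 2.3-fold higher number from compound 2 to compound 4 (0.36 log units; beyond the scatter), so the drop in the number seen with 2-fluorophenyl does not carry over to this other substituted phenyl. The steps to compound 4 from compound 1 and from compound 3 join two limits and cannot be read. Of the groups shown on this chain carbon, only the 2-fluorophenyl of compound 2 gives a measured number, while the other three compounds share one limit: the limit of > 10000 nM in this assay, at which 3 of the 4 values shown sit.

On these data alone, how far compound 1, compound 3 and compound 4 lie beyond that limit stays unknown, so they cannot be ranked against one another. Also open, as far as these compounds go, is whether an unsubstituted phenyl or a chain ending in an amine would bring the number down as 2-fluorophenyl does.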